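A few compounds are considered here, and "the series" means these few. Any claim that something is new, unique, unknown or untested is made for them only; others in the source may bear on it.

Compound 1, `C=CC1=C(C(=O)NCCCCC)C(c2ccc(OC)cc2)OC1`. In a functional assay on SW480 cells (Homo sapiens) for cytotoxicity, read by MTT assay, with a stated time of 24 h (on this read-out higher numbers stand for weaker inhibition and lower numbers for stronger inhibition), compound 1 gives only a limit, > 100000 nM.
Compound 2, `C=CC1=C(C(=O)NCCC)C(c2ccc(OC)c(OC)c2)OC1`. In this assay compound 2 likewise reaches only a limit, > 100000 nM.
Compound 3, `C=CC1=C(C(=O)NCc2ccc(C)cc2)C(c2ccc(F)cc2)OC1`. In this assay compound 3 also stops at a limit, > 100000 nM.

For the measured compounds named here, compound 1 therefore cannot be placed against the other two: its value is a limit rather than a number, and the same holds for compound 2 and compound 3, so there is no ordering among them and no step between measured compounds can be computed. All that the numbers show is the limit of > 100000 nM in this assay, at which 3 of the 3 values shown sit.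

Compound 4, `C=CC1=C(C(=O)Nc2ccc(C)cc2)C(c2ccc(OC)cc2)OC1`, is the next member of this series. It differs from compound 1 by 4-methylphenyl in place of pentyl on an amide-type nitrogen. Going by the values given here, with three limits and no measured step to lean on, the expected outcome is that this change moves the value by nothing beyond the scatter, which is what the expected step that the limit leaves unreadable from compound 1 to compound 4 means. Compound 4 is therefore estimated at 150000 nM in this assay, with a range from 50000 nM to 500000 nM, and most likely the assay will again report only a limit.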

Compound 4, half-maximal inhibitory concentration: > 100000 nM
Compound 4: only a limit was reported (the forecaster's own chance of this, stated with the estimate: 80%); the middle value is on the limit's open side.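

Compound 1 and compound 4 both give only a limit in this assay, so no step between them can be read: the limit of > 100000 nM in this assay, at which 4 of the 4 values shown sit.

The compounds shown leave open whether any change on the shared core would give a measurable value in this assay.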